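The compounds below may be only part of what the source reports. "The series", "measured", "known", "first", "only" and "open" are said of these compounds alone.

Within the data shown here, in an ADME assay on Hepa-1c1c7 cells (Mus musculus) for cytotoxicity (a lower number here means a stronger inhibitor, a higher number a weaker inhibitor), compound 1 `C=CCCCCC/C=C\C(O)C#CC#C[C@@H](O)[C@H](C)O` gives 88600 nM, the only actual number among the compounds measured so far. Compound 2 `C[C@H](O)[C@H](O)C#CC#CC(O)Cc1ccccc1` returned only a limit, > 500000 nM. Compound 3 `C=CCCCCC/C=C\C(O)C#CC#C[C@H](O)[C@H](C)O` has yet to be measured in this assay. It departs from compound 1 in stereochemistry alone: the two compounds have the same atoms and bonds; at least one stereo element is drawn with a configuration in one of them and without one in the other: 1 of 4 stereo elements differ; a stereocentre at a saturated chain carbon is drawn R in compound 1 and S in compound 3. The two compounds have the same atoms and bonds. Among the measured compounds shown here, no measured pair here shows what such an inversion does, so no step beyond the usual scatter is expected in this assay, and neither direction is favoured. The expected 1.0-fold higher number from compound 1 to compound 3 (0.01 log units; within the scatter) is therefore small. Resting on the value of compound 1, 88600 nM, the estimate for compound 3 is an expected 90000 nM, with an estimated range from 40000 nM to 200000 nM.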

Compound 3, half-maximal inhibitory concentration: 252000 nM
Compound 3: the middle estimate sits 2.8-fold (0.45 log units) below what was measured; the whole stated range lies below it.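

In this assay, inverting the stereocentre at the saturated chain carbon from R to S, with atoms and bonds unchanged, gives a 2.8-fold higher number from compound 1 to compound 3 (0.45 log units; beyond the scatter). Configuration at this one position is thus enough to move the number beyond the scatter, toward weaker inhibition in the S form, which the earlier compounds could not show because compounds 1 and 2 differ in more than one place. The reading carries one caution: the fact that one of compounds 1 and 3 is drawn with a defined configuration and the other without, at the place where they differ.

Compound 2 gives only a limit, > 500000 nM. Going by these compounds, whether inverting the other stereocentres would shift the number in the same direction remains open, as does the effect of an amine in place of a hydroxyl group at this position.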